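Chain extension on the amide side of the shared core

The compounds below may be only part of what the source reports. "The series", "measured", "known", "first", "only" and "open" are said of these compounds alone.

Three compounds share a core and differ in the group attached to the aromatic carbon of the aniline. Compound 1 `CN(C)C(=O)c1cc2cnc(Nc3ccc(S(=O)(=O)NCCCN=C=S)cc3)nc2n1C1CCCC1` gives 72.8% in a functional assay on NCI-H1299 cells (Homo sapiens) for inhibition, read by CCK-8 assay, with a stated time of 72 h, tested at 10 uM; on this read-out lower numbers stand for a weaker effect and higher numbers for a stronger effect at the one concentration tested. Compound 2 `CN(C)C(=O)c1cc2cnc(Nc3ccc(S(=O)(=O)NCCCCN=C=S)cc3)nc2n1C1CCCC1`, which carries the longer chain, gives 72.7%, so the step of a number 0.1 percentage points lower from compound 1 to compound 2 (within the scatter). Compound 3 `CN(C)C(=O)c1cc2cnc(Nc3ccc(NC(=O)CCCN=C=S)cc3)nc2n1C1CCCC1`, with the amide-linked chain, gives 78.8%. Compound 3 stands highest of the three numbers, but its steps to compound 1 and to compound 2 are both within the scatter, so no order among them can be claimed.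

Compound 4 `CN(C)C(=O)c1cc2cnc(Nc3ccc(NC(=O)CCCCN=C=S)cc3)nc2n1C1CCCC1` is not yet measured. It differs from compound 3 by a group of 4 heavy atoms (2 carbon, 1 nitrogen, 1 sulfur; no ring) in place of a group of 3 heavy atoms (1 carbon, 1 nitrogen, 1 sulfur; no ring), on a saturated chain carbon, three bonds along the chain from a carbonyl carbon. The step from compound 1 to compound 2 is the same kind of lengthening, carried out on the sulfonamide side, and there it gave a number 0.1 percentage points lower from compound 1 to compound 2 (within the scatter). On that basis no step beyond the scatter is expected for compound 4, and its value is estimated at 78%, with a range from 66% to 88%. The expected step of a number 0.8 percentage points lower from compound 3 to compound 4 (within the scatter) is therefore essentially flat.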

Compound 4, a percentage reported as inhibition, at one concentration (the size of the read-out at that concentration, not a potency): 82.5%
For compound 4 the middle estimate is 4.5 percentage points below the measured one; the measured number falls inside the stated range.
By their numbers in this assay, from the lowest: compounds 2, 1, 3 and 4 (each within the scatter of the next).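

The same lengthening has now been seen on both the sulfonamide-linked and the amide-linked chains, and in this assay it does not move the number beyond the scatter on either: the same change on two cores in this assay, a number 0.1 percentage points lower (within the scatter) from compound 1 to compound 2 and a number 3.7 percentage points higher (within the scatter) from compound 3 to compound 4, 3.8 percentage points apart, within the scatter of two such steps. On the amide-linked chain alone, the change reads as a number 3.7 percentage points higher from compound 3 to compound 4 (within the scatter), so the flat result seen on the sulfonamide side also holds here. Set against the sulfonamide-linked compounds, the longer amide-linked chain gives a number 9.8 percentage points higher from compound 2 to compound 4 (within the scatter) and a number 9.7 percentage points higher from compound 1 to compound 4 (within the scatter), so the swap of linker does not separate these compounds either.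

The compounds shown leave open whether a still longer chain, or an amine or a carboxylic acid in place of the group that enters here, would give a step beyond the scatter. For the compounds shown here, with all four read at a single concentration, they show only the size of the effect at that concentration, and no compound can be said to have a stronger or weaker effect there than another.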